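A few compounds are considered here, and "the series" means these few. Any claim that something is new, unique, unknown or untested is made for them only; others in the source may bear on it.

Compound 1 `CCCCCCOC(=O)/C=C/c1ccc(NC(=O)C2(NC(=O)c3ccc4c(C5CCCC5)c(-c5ncc(Cl)cn5)n(C)c4c3)CCC2)cc1OCC` gives 12.7 h in an ADME assay (liver) for pharmacokinetics, with Liver microsome (Rattus norvegicus) as the target, using microsomes; on this read-out lower numbers stand for a shorter-lived compound and higher numbers for a longer-lived compound; compound 2 `CCOc1cc(NC(=O)C2(NC(=O)c3ccc4c(C5CCCC5)c(-c5ncc(Cl)cn5)n(C)c4c3)CCC2)ccc1/C=C/C(=O)OCC(Cl)(Cl)Cl` gives 0.233 h; compound 3 `CCOc1cc(NC(=O)C2(NC(=O)c3ccc4c(C5CCCC5)c(-c5ncc(Cl)cn5)n(C)c4c3)CCC2)ccc1/C=C/C(=O)OCCOCCOC` gives 1.07 h.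

Compound 3 holds the second highest of the three half-lives: its nearest neighbour is compound 2, with a 4.6-fold higher number from compound 2 to compound 3 (0.66 log units; beyond the scatter), while compound 1 lies furthest away, with a 12-fold lower number from compound 1 to compound 3 (1.07 log units; beyond the scatter). Compound 4 `CCCN(C)C(=O)COC(=O)/C=C/c1ccc(NC(=O)C2(NC(=O)c3ccc4c(C5CCCC5)c(-c5ncc(Cl)cn5)n(C)c4c3)CCC2)cc1OCC` differs from compound 3 in one place: methyl(propyl)carbamoyl in place of (2-methoxyethoxy)methyl on a saturated chain carbon bound to an oxygen next to a carbonyl group. Two measured steps change the group at that same place, namely a 55-fold lower number from compound 1 to compound 2 (1.74 log units; beyond the scatter) and a 4.6-fold higher number from compound 2 to compound 3 (0.66 log units; beyond the scatter), so swaps there have moved this assay by large to modest amounts in both directions. Compound 4 is therefore expected to shift by a modest step, estimated as a 1.4-fold higher number from compound 3 to compound 4 (0.15 log units; within the scatter). Compound 4 is estimated at 1.5 h, within 0.3 h to 6 h.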

Compound 4, half-life: 0.317 h
Estimate against measurement, compound 4: 4.7-fold (0.68 log units) above, within the range that was stated.
By their numbers in this assay, from the lowest: compounds 2 and 4 (each within the scatter of the next); then compound 3; then compound 1.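

In this assay the methyl(propyl)carbamoyl group on this saturated chain carbon gives a 3.4-fold lower number from compound 3 to compound 4 (0.53 log units; beyond the scatter) and a 40-fold lower number from compound 1 to compound 4 (1.60 log units; beyond the scatter), so the long half-life still rests with the pentyl of compound 1 alone. Set against trichloromethyl, the same group gives a 1.4-fold higher number from compound 2 to compound 4 (0.13 log units; within the scatter), which shows that two very different groups can read alike at this place. Nothing available here accounts for these differences.

From the compounds shown here alone, whether half-life follows chain length among plain alkyl groups such as butyl or octyl remains open. So does what a morpholine amide or a carboxylic acid would give on this carbon.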